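Swapping a Phenylethenyl Arm for a Propyl Chain

The source may hold more compounds than are shown below. What is called first, only, known or untested is meant among the compounds shown, and "the series" means these compounds.

Measured so far in a functional assay on MCF7 cells (Homo sapiens) for cytotoxicity, read by sulforhodamine B assay, with a stated time of 48 h; on this read-out lower numbers stand for stronger inhibition and higher numbers for weaker inhibition:
- compound 1 `COc1ccc2c(c1)c(/C=N/O)cn2Cc1cn([C@@H]2O[C@H](COC(C)=O)[C@@H](OC(C)=O)[C@H](OC(C)=O)[C@H]2OC(C)=O)nn1` gives 51000 nM
- compound 2 `CC(=O)OC[C@H]1O[C@@H](n2cc(CN3C(=O)/C(=C\C=C\c4ccccc4)c4ccccc43)nn2)[C@H](OC(C)=O)[C@@H](OC(C)=O)[C@@H]1OC(C)=O` gives 34100 nM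
- compound 3 `CC(=O)OC[C@H]1O[C@@H](n2cc(CN3C(=O)/C(=C/C=C/c4ccccc4)c4ccccc43)nn2)[C@H](OC(C)=O)[C@@H](OC(C)=O)[C@@H]1OC(C)=O` gives 53200 nM

All three numbers are high, meaning weak inhibition, and compound 3 sits within the scatter of both compound 1 and compound 2 in this assay. Among the compounds with values here, the only single-point step among them is a 1.6-fold higher number from compound 2 to compound 3 (0.19 log units; within the scatter), which comes from the fact that compounds 2 and 3 differ only in the configuration as drawn and does not reach beyond the scatter.

Compound 4 `CCC/C=C1/C(=O)N(Cc2cn([C@@H]3O[C@H](COC(C)=O)[C@@H](OC(C)=O)[C@H](OC(C)=O)[C@H]3OC(C)=O)nn2)c2ccccc21` is built from compound 3 by the change (propyl in place of 2-phenylethenyl on a double-bonded chain carbon bound to a double-bonded ring carbon). Within the data shown here, no measured step touches this kind of replacement, so there is nothing in the data that points to a sizeable shift in either direction. The step from compound 3 to compound 4 is therefore expected to be small, a 1.1-fold higher number from compound 3 to compound 4 (0.05 log units; within the scatter), with a wide band of uncertainty. For compound 4 the estimated value in this assay is 60000 nM, with a range from 25000 nM to 150000 nM.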

Compound 4, half-maximal inhibitory concentration: 22600 nM
Beside the measured number, compound 4's estimate is 2.7-fold (0.42 log units) above it; the measured number lies below the stated range.
By their numbers in this assay, from the lowest: compounds 4, 2, 1 and 3 (each within the scatter of the next, the first and the last beyond it).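

In this assay, this is the only step among the compounds shown that goes beyond the scatter: putting propyl in place of 2-phenylethenyl gives a 2.4-fold lower number from compound 3 to compound 4 (0.37 log units; beyond the scatter), a modest step. On a double-bonded chain carbon bound to a double-bonded ring carbon, then, the aromatic ring and the extra double bond of the arm are not required to keep this cytotoxicity, although the numbers remain high, which means weak inhibition. Nothing in the data at hand accounts for the size or direction of this step.

The ring, the chain double bond and the chain length all change in this one step, and the step does not separate them. As far as these compounds go, whether methyl, a longer chain such as hexyl, or a saturated 2-phenylethyl group would follow propyl or 2-phenylethenyl at this place remains open.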